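The source may hold more compounds than are shown below. What is called first, only, known or untested is meant among the compounds shown, and "the series" means these compounds.

Compound 1 `O=C1C(Nc2ccc(Br)cc2)=CC(=O)c2c1nc1n2[C@H]2OC[C@@H](O)[C@H]2OC1` is tested in a functional assay on ECa-109 cells for inhibition, with ECa-109 cell line (Homo sapiens) as the target, read by sulforhodamine B assay (a higher number here means a weaker inhibitor, a lower number a stronger inhibitor), where compound 1 gives 1980 nM. Among the two plain numbers shown it is the lowest; its neighbour, compound 2 `O=C1C=C(Nc2ccccc2F)C(=O)c2c1nc1n2[C@H]2OC[C@@H](O)[C@H]2OC1`, gives 2760 nM in this assay, a difference that stays within the usual scatter, so the two compounds cannot be told apart. Compound 3 `O=C1C=C(NC2CCCCC2)C(=O)c2c1nc1n2[C@H]2OC[C@@H](O)[C@H]2OC1` reaches only the limit of > 16000 nM in this assay, at which 1 of the 3 values shown sits, in this assay, a limit of the assay rather than a number, reported for compound 3 as > 16000 nM. For the measured compounds named here, the one measured step runs an at least 5.7-fold higher number from compound 2 to compound 3 (0.76 log units; beyond the scatter), so exchanging a six-membered aromatic ring of carbon only for a saturated cyclohexyl on the amine nitrogen clearly weakened inhibition.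

The unmeasured compound 4 `O=C1C(NCc2ccccc2)=CC(=O)c2c1nc1n2[C@H]2OC[C@@H](O)[C@H]2OC1` differs from compound 1 by benzyl in place of 4-bromophenyl on an amine nitrogen. This change keeps one six-membered aromatic ring of carbon only but moves it one carbon further from the amine nitrogen, a change in between keeping the ring, as in compound 1 and compound 2, and removing it, as in compound 3. A modest rise in the number is therefore expected, smaller than the step from compound 2 to compound 3. The expected step is a 2.3-fold higher number from compound 1 to compound 4 (0.36 log units; beyond the scatter). Compound 4 is estimated at 4500 nM, with a range from 1500 nM to 14000 nM.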

Compound 4, half-maximal inhibitory concentration: > 8000 nM
Compound 4: a limit, no number; the forecaster's own chance of this, stated with the estimate: 10%; at least 1.7-fold (0.24 log units) between middle value and limit.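

The reading for compound 4 is a limit, not a number: the limit of > 8000 nM in this assay, at which 1 of the 4 values shown sits. Even so, the change can be read in one direction, as an at least 4.0-fold higher number from compound 1 to compound 4 (0.60 log units; beyond the scatter), so on this amine nitrogen benzyl gives weaker inhibition than 4-bromophenyl. The earlier step, an at least 5.7-fold higher number from compound 2 to compound 3 (0.76 log units; beyond the scatter), could be taken as a simple contrast between having a six-membered aromatic ring of carbon only and having none, but here that ring stays in the molecule and inhibition still weakens, so its presence alone is not enough to hold the activity of compound 1.

The change from compound 1 to compound 4 both removes the bromine and puts one carbon between the ring and the amine nitrogen, so the compounds shown cannot say which of the two matters, and the limit leaves the full size of the step unknown. A plain phenyl on the same amine nitrogen would separate the bromine from the extra carbon, while a 4-bromobenzyl would test whether bromine still counts once the ring sits one carbon further out.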